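Returning toward compound 1 with an added hydroxyl

A few compounds are considered here, and "the series" means these few. Any claim that something is new, unique, unknown or untested is made for them only; others in the source may bear on it.

Compound 2, `CC(C)(C)c1ccc(S(=O)(=O)Nc2ccc(Cl)cc2-c2c(O)ccc[n+]2[O-])cc1`, gives 491 nM in a functional assay on isolated protein for antagonist activity at C-C chemokine receptor type 9 (Homo sapiens), read by calcium flux, with a stated time of 10 min (on this read-out lower numbers stand for stronger inhibition and higher numbers for weaker inhibition), and thereby stands at the highest of the two numbers recorded; its nearest neighbour is compound 1, `CC(C)(C)c1ccc(S(=O)(=O)Nc2ccc(Cl)cc2-c2ncccc2CO)cc1`, which in this assay gives 89 nM. Going by the values given here, the one measured step between them, a 5.5-fold higher number from compound 1 to compound 2 (0.74 log units; beyond the scatter), shows that the exchange of the ring group has a real effect. Compound 3, `CC(C)(C)c1ccc(S(=O)(=O)Nc2ccc(Cl)cc2-c2nccc(CO)c2O)cc1`, is the next compound to be measured. It differs from compound 2 in that (a group of 9 heavy atoms (6 carbon, 1 nitrogen, 2 oxygen; one six-membered aromatic ring with 1 hetero atom) in place of a group of 8 heavy atoms (5 carbon, 1 nitrogen, 2 oxygen; one six-membered aromatic ring with 1 hetero atom), on an aromatic carbon), on an aromatic carbon of a six-membered aromatic ring of carbon only, ortho to a large group and meta to a chloro group. Among the compounds with values here, only the step from compound 1 to compound 2 bears on this change, and compound 3 carries a ring group that resembles the one in compound 1 more than the one in compound 2. Compound 3 is therefore expected to give a lower number than compound 2, a step of a 3.3-fold lower number from compound 2 to compound 3 (0.51 log units; beyond the scatter), landing at about 150 nM with a range from 50 nM to 500 nM.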

Compound 3, half-maximal inhibitory concentration: 8.7 nM
The estimate for compound 3 lay 17-fold (1.24 log units) above the measured number; measured number below the stated range.
By their numbers in this assay, from the lowest: compound 3; then compound 1; then compound 2.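

At this position, on an aromatic carbon of a six-membered aromatic ring of carbon only, ortho to a large group and meta to a chloro group, the exchange of the ring group can shift the number much further than the first step showed: in this assay, the change gives a 56-fold lower number from compound 2 to compound 3 (1.75 log units; beyond the scatter), a large step. The entering group also does more than restore what compound 2 lost, since the comparison with the earlier lead gives a 10-fold lower number from compound 1 to compound 3 (1.01 log units; beyond the scatter), which makes compound 3 the strongest of the three, with both of its steps beyond the scatter. Nothing on hand accounts for the size of these steps or says which feature of the entering group produces them.

The compounds shown do not separate the contributions of the hydroxyl and the hydroxymethyl on the entering ring, so it remains unclear whether the two must occur together for the low number to appear. On these data alone, how a methoxy group in place of the hydroxyl, or an amine or a carboxylic acid in place of the hydroxymethyl, would read in this assay also stays open.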